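This account rests on a few compounds, and the source may have more. Where it says the series, first, only, none or still open, it means among the compounds named here.

Measured compounds:
compound 1 `CCC(CC)S(=O)(=O)c1ccc(S(=O)(=O)N2CCC[C@@H](C(=O)N3CCC(F)(F)CC3)C2)cc1` — 13 nM
compound 2 `O=C([C@@H]1CCCN(S(=O)(=O)c2ccc(S(=O)(=O)C3CCC3)cc2)C1)N1CCC(F)(F)CC1` — 9 nM

In a functional assay on MIA PaCa-2 cells (Homo sapiens) for inhibition, read by MTT assay, with a stated time of 7 days (on this read-out lower numbers stand for stronger inhibition and higher numbers for weaker inhibition), compound 1 gives 13 nM, and compound 2 gives 9 nM. Among the measured compounds shown here, compound 2 has the lowest of the two numbers, but the only step that connects them, a 1.4-fold lower number from compound 1 to compound 2 (0.16 log units; within the scatter), lies within the scatter, so the two compounds cannot be placed in order on these data.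

The next compound, compound 3 `CC(C)S(=O)(=O)c1ccc(S(=O)(=O)N2CCC[C@@H](C(=O)N3CCC(F)(F)CC3)C2)cc1`, differs from compound 2 by the change (isopropyl in place of cyclobutyl on a sulfonyl sulfur). For the measured compounds named here, the one measured step that bears on this change is the exchange of the group on the same sulfonyl sulfur, a 1.4-fold lower number from compound 1 to compound 2 (0.16 log units; within the scatter), which was small. Going by the values given here, with only that step to go by, a change from the cyclobutyl group to an isopropyl group at the same place is expected to move the number in this assay by little, if at all, beyond the scatter.

For compound 3 the estimated step is a 1.3-fold higher number from compound 2 to compound 3 (0.12 log units; within the scatter). Compound 3 is therefore expected to give about 12 nM in this assay, with a range from 5 nM to 30 nM.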

Compound 3, half-maximal inhibitory concentration: 11 nM
Compound 3: middle estimate off by 1.1-fold (0.04 log units), on the high side, and the stated range covers the measured number.
By their numbers in this assay, from the lowest: compounds 2, 3 and 1 (each within the scatter of the next).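

In this assay, isopropyl in place of cyclobutyl on the sulfonyl sulfur gives a step that stays within the scatter (a 1.2-fold higher number from compound 2 to compound 3 (0.09 log units; within the scatter)), and isopropyl in place of pentan-3-yl does the same (a 1.2-fold lower number from compound 1 to compound 3 (0.07 log units; within the scatter)). With a third group at this place, all three compounds now lie within the scatter of one another, so the data give no order among cyclobutyl, isopropyl and pentan-3-yl. Cyclobutyl is the only one of the three that carries a ring, and the numbers show that, among these compounds, the four-membered ring is not needed for a value of this size, while no explanation for this flat result is available from any supporting data.

All three groups are plain carbon groups joined to the sulfonyl sulfur, so the compounds shown leave open what an amine, a carboxylic acid, a methyl group or a long straight chain would do at this place. They also leave open whether the same flat picture would hold with a different group in place of the shared core's other parts, since only this one place varies here.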